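The source may hold more compounds than are shown below. What is called first, only, known or untested is meant among the compounds shown, and "the series" means these compounds.

Three compounds share a core in which a phenol-bearing benzylic amine is linked to an aniline ring; they differ in the group carried on that aniline. Compound 1 `Oc1ccccc1CNc1ccc(F)cc1` carries a fluorine there, and in a functional assay on Jurkat cells (Homo sapiens) for activation, with a stated time of 24 h (on this read-out higher numbers stand for an effect only at larger amounts of compound and lower numbers for an effect already at smaller amounts), compound 1 is reported as "not active" (no number reported). Compound 2 `Oc1ccccc1CNc1ccc(N2CCCC2)cc1` carries a pyrrolidine, and in this assay compound 2 is likewise reported as "not active" (no number reported). Compound 3 `Oc1ccccc1CNc1ccc(-c2ccccc2)cc1` carries a phenyl, and in this assay compound 3 gives 1820 nM. Within the data shown here, compound 3 therefore stands as the one member of the set with a measured number in this assay; the other two give no number at all.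

Compound 4 `CC(C)(C)c1ccc(-c2ccc(NCc3ccccc3O)cc2)cc1` extends compound 3 by one change: tert-butyl in place of hydrogen on an aromatic carbon. Among the measured compounds shown here, no measured pair shows the effect of this change, so the step can only be anticipated. The step from a 1.7-fold lower number from compound 3 to compound 4 (0.22 log units; within the scatter) is expected to be small, within or at the edge of the usual scatter, with a slight lean towards lower concentration. On that basis compound 4 is estimated at 1100 nM in this assay, with a plausible range from 300 nM to 4000 nM.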

Compound 4, half-maximal effective concentration: "not active" (no number reported)
Compound 4: no number reported, so the estimate cannot be set against anything.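

Among these compounds, with compound 4 reported without a number in this assay, no step from compound 3 to compound 4 can be read. No measured evidence bears on this result. The compounds shown leave open how substituents on the phenyl of compound 3 affect activation.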